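The source may report more compounds than this note shows. Statements on the series, on what has been measured and on what is new or still open speak of the compounds shown alone.

Measured so far in a physicochemical assay for solubility, in phosphate buffer, at pH 7.4; on this read-out higher numbers stand for higher solubility and lower numbers for lower solubility:

compound 1 `O=C(O)CCCCCNC(=O)NC1CCCCC1`: > 500000 nM
compound 2 `N=C(N)NCCC[C@H](NC(=O)CCCCCNC(=O)NC1CCCCC1)C(=O)O`: > 500000 nM

Compound 1 gives > 500000 nM, and this is a limit of the assay and not a number. Compound 2 gives > 500000 nM, which is likewise a limit. The two measured compounds therefore share one reading, (the limit of > 500000 nM in this assay, at which 2 of the 2 values shown sit), and neither has an exact value in this assay.

Compound 3 `COC(=O)CCCCCNC(=O)NC1CCCCC1` has not yet been measured. It differs from compound 1 by methyl in place of hydrogen on an oxygen next to a carbonyl group, so that carboxy becomes methoxycarbonyl. Among the compounds with values here, no measured pair shows this change, so the size of the step cannot be read from the data and remains a judgement. A downward move in this assay is expected, and it is expected to be larger than the usual scatter of repeated measurements. The estimated step is an at least 3.3-fold lower number from compound 1 to compound 3 (0.52 log units; beyond the scatter). For compound 3 the expected solubility is 150000 nM, with an estimated range from 40000 nM to 500000 nM.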

Compound 3, solubility: > 500000 nM
Compound 3 ended at the assay's limit; the forecaster's own chance of this, stated with the estimate: 15%; middle value at least 3.3-fold (0.52 log units) away from the limit.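

In this assay compound 3 gives > 500000 nM, which is a limit and not a number. Within the data shown here, no step from compound 1 to compound 3 can be read, because both stand at the same limit: the limit of > 500000 nM in this assay, at which 3 of the 3 values shown sit. How far any of these compounds lies past that limit stays open, as does whether methoxycarbonyl in place of carboxy changes the read-out at all.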